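The compounds below may be only part of what the source reports. "The series", "measured", "known", "first", "only" and "open" are said of these compounds alone.

Compound 3 `CC(C)(C)c1ccc(N2C(=O)NC3(CSC4=C3C(=O)c3ncccc3C4=O)C2=O)cc1` stands with the highest number among the three measured compounds in a functional assay on HeLa cells (Homo sapiens) for antiproliferative activity, read by MTT assay, with a stated time of 96 h; on this read-out lower numbers stand for stronger inhibition and higher numbers for weaker inhibition: compound 3 gives 100 nM. Its nearest neighbour, compound 1 `CN(C)c1ccc(N2C(=O)NC3(CSC4=C3C(=O)c3ncccc3C4=O)C2=O)cc1`, gives 10 nM, and compound 2 `Cc1ccc(N2C(=O)NC3(CSC4=C3C(=O)c3ncccc3C4=O)C2=O)cc1` gives 2 nM. The shared core is kept throughout; only the group on the amide-type nitrogen in the ring changes. Compound 4 `O=C1C2=C(C(=O)c3ncccc31)C1(CS2)NC(=O)N(c2ccncc2)C1=O` carries the change (pyridin-4-yl in place of 4-(tert-butyl)phenyl on an amide-type nitrogen in a ring).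

Among the measured compounds shown here, no measured step involves a pyridin-4-yl, so the bearing of the earlier steps is indirect. Both steps that reach compound 3 show that a tert-butyl on the aromatic carbon goes with higher numbers: a 10-fold higher number from compound 1 to compound 3 (1.00 log units; beyond the scatter) and a 50-fold higher number from compound 2 to compound 3 (1.70 log units; beyond the scatter). Removing the tert-butyl therefore points toward a lower number in this assay, though the nitrogen in the entering ring has no measured parallel.

Compound 4 is expected to give 15 nM in this assay, with a range from 3 nM to 80 nM. This estimate implies the step of a 6.7-fold lower number from compound 3 to compound 4 (0.82 log units; beyond the scatter), a lowering expected to exceed the scatter.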

Compound 4, half-maximal inhibitory concentration: 10 nM
Beside the measured number, compound 4's estimate is 1.5-fold (0.18 log units) above it; measured number inside the range.
By their numbers in this assay, from the lowest: compound 2; then compounds 1 and 4 (each within the scatter of the next); then compound 3.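

In this assay, the amide-type nitrogen in the ring tolerates an aromatic ring with a hetero atom: the pyridin-4-yl ring gives a clear gain over 4-(tert-butyl)phenyl (a 10-fold lower number from compound 3 to compound 4 (1.00 log units; beyond the scatter)) and cannot be told apart from 4-(dimethylamino)phenyl (no change at the digits printed from compound 1 to compound 4 (within the scatter)). It does not match 4-methylphenyl, however (a 5.0-fold higher number from compound 2 to compound 4 (0.70 log units; beyond the scatter)), so compound 2 keeps the lowest number of the four and the ring nitrogen brings no gain over that group. Nothing shown here gives a measured reason for these differences.

On these data alone, it remains open whether pyridin-3-yl or pyridin-2-yl at this nitrogen would behave like pyridin-4-yl. Also open, as far as these compounds go, is whether a methyl group on the pyridine ring would bring the number closer to that of compound 2 (2 nM).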